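The source may report more compounds than this note shows. Statements on the series, on what has been measured and on what is new or still open speak of the compounds shown alone.

In a functional assay on CHO-K1 cells for antagonist activity at transient receptor potential cation channel subfamily V member 1 (Homo sapiens), read by FLIPR (on this read-out lower numbers stand for stronger inhibition and higher numbers for weaker inhibition), compound 1 `CC(C(=O)NCc1ccc(C(F)(F)F)nc1N1CC=CCC1)c1ccc(NS(C)(=O)=O)c(F)c1` gives 0.3 nM. Compound 2 `CC(C(=O)NCc1ccc(C(F)(F)F)nc1N1CCC(C(F)(F)F)CC1)c1ccc(NS(C)(=O)=O)c(F)c1` gives 0.6 nM in this assay, and the change between them is a 2.0-fold higher number from compound 1 to compound 2 (0.30 log units; within the scatter). Compound 3 `CCCCOC1CCN(c2nc(C(F)(F)F)ccc2CNC(=O)C(C)c2ccc(NS(C)(=O)=O)c(F)c2)CC1` gives 3.5 nM in this assay, the highest of the three numbers: a 12-fold higher number from compound 1 to compound 3 (1.07 log units; beyond the scatter), while a 5.8-fold higher number from compound 2 to compound 3 (0.77 log units; beyond the scatter). Compound 4 `CC(C)OC1CCN(c2nc(C(F)(F)F)ccc2CNC(=O)C(C)c2ccc(NS(C)(=O)=O)c(F)c2)CC1` differs from compound 3 in one place: isopropyl in place of butyl on an oxygen on a saturated carbon. Among the measured compounds shown here, no measured pair shows this exchange of one alkyl group for another on the oxygen, so the nearest guide is the modest rise seen in a 5.8-fold higher number from compound 2 to compound 3 (0.77 log units; beyond the scatter), which came with the arrival of the butoxy group in that place. Trading butyl for isopropyl keeps an alkoxy group there, so the number is expected to stay close to that of compound 3, perhaps a little lower, and the expected step is a 1.4-fold lower number from compound 3 to compound 4 (0.15 log units; within the scatter). Compound 4 is therefore expected to give about 2.5 nM in this assay, with a range from 0.7 nM to 9 nM.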

Compound 4, inhibition constant: 3 nM
Compound 4: the middle estimate sits 1.2-fold (0.08 log units) below what was measured; the measured number falls inside the stated range.
By their numbers in this assay, from the lowest: compounds 1 and 2 (each within the scatter of the next); then compounds 4 and 3 (each within the scatter of the next).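

In this assay, exchanging butoxy for isopropoxy on this saturated ring carbon gives a 1.2-fold lower number from compound 3 to compound 4 (0.07 log units; within the scatter), so this first look at a change of the alkyl group on the oxygen shows no difference that can be told from the scatter. The higher numbers seen with butoxy therefore also appear with isopropoxy, at a 5.0-fold higher number from compound 2 to compound 4 (0.70 log units; beyond the scatter) and a 10-fold higher number from compound 1 to compound 4 (1.00 log units; beyond the scatter), both beyond the scatter. Nothing measured here offers a reason for these numbers.

Going by these compounds, whether a methoxy, a hydroxyl or an amine on this ring carbon would bring the number back towards that of compound 2 remains open. So does the question of how a longer chain, such as hexyloxy, would read in the same place.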